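The compounds below may be only part of what the source reports. "The series", "measured", "known", "first", "only" and "open" are said of these compounds alone.

The shared core carries two cinnamoyl-type arms on a hydroxylated, methylated ring, with a pendant aryl group whose substitution varies. Compound 1 `Cc1cc(O)c(C(=O)/C=C/c2ccccc2Cl)c(-c2ccccc2)c1C(=O)/C=C/c1ccccc1Cl` has an unsubstituted phenyl at that position; in a functional assay on MCF7 cells (Homo sapiens) for cytotoxicity, read by MTT assay, with a stated time of 24 h (on this read-out lower numbers stand for stronger inhibition and higher numbers for weaker inhibition), compound 1 is recorded as "not active" (no number reported), so no single number places it on the scale. Two measured relatives give some bearings. Compound 2 `Cc1cc(O)c(C(=O)/C=C/c2ccccc2)c(-c2ccc(Br)cc2)c1C(=O)/C=C/c1ccccc1` carries a bromine on the pendant phenyl, and in this assay compound 2 gives 10000 nM. Compound 3 `Cc1cc(O)c(C(=O)/C=C/c2ccc(F)cc2)c(-c2ccc(OCc3ccccc3)cc2)c1C(=O)/C=C/c1ccc(F)cc1` carries a benzyloxy group there and fluorine on both arms, and in this assay compound 3 gives 28000 nM. Compound 4 `Cc1cc(O)c(C(=O)/C=C/c2ccccc2Cl)c(-c2ccc(Cl)cc2)c1C(=O)/C=C/c1ccccc1Cl` differs from compound 1 by chloro in place of hydrogen on an aromatic carbon. Going by the values given here, with no measured step between compound 1 and compound 4, and compound 1 without a number, only a direction can be guessed: compound 2 shows that a halogen on the pendant ring is compatible with a measurable number, so a move from inactive toward a weak, measurable value is expected, though the chance of another limit remains real. Compound 4 is expected to give about 20000 nM, estimated between 7000 nM and 60000 nM.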

Compound 4, half-maximal inhibitory concentration: 30000 nM
Estimate against measurement, compound 4: 1.5-fold (0.18 log units) below; measured number inside the range.
By their numbers in this assay, from the lowest: compound 2; then compounds 3 and 4 (each within the scatter of the next).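

Compound 1 is recorded as "not active" (no number reported) and compound 4 gives 30000 nM, so no step can be read between them. The compounds shown leave open how far the phenyl to 4-chlorophenyl change moves the value on the shared core. No supporting evidence bears on this result.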